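This account rests on a few compounds, and the source may have more. Where it says the series, first, only, none or still open, it means among the compounds named here.

Working notes on the series built on the core of compound 1 `CCOC(=O)C1=Cc2ccccc2OC1(OCc1cn(-c2ccc(F)cc2)nn1)C(F)(F)F`. In a functional assay on MCF7 cells (Homo sapiens) for inhibition, read by MTT assay, with a stated time of 24 h (a lower number here means a stronger inhibitor, a higher number a weaker inhibitor), compound 1 gives 9100 nM, the lowest of the two numbers recorded. Compound 2 `CCOC(=O)C1=Cc2ccccc2OC1(OCc1cn(-c2ccc(C)cc2)nn1)C(F)(F)F` gives 26700 nM in this assay, so that a 2.9-fold higher number from compound 1 to compound 2 (0.47 log units; beyond the scatter). Compound 3 `CCOC(=O)C1=Cc2ccccc2OC1(OCc1cn(CC(=O)Nc2ccccc2Br)nn1)C(F)(F)F` is reported in this assay only as a limit, > 150000 nM. Measured against that limit, an at least 16-fold higher number from compound 1 to compound 3 (1.21 log units; beyond the scatter) and an at least 5.6-fold higher number from compound 2 to compound 3 (0.74 log units; beyond the scatter).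

Compound 4 `CCOC(=O)C1=Cc2ccccc2OC1(OCc1cn(CC(=O)Nc2ccccc2F)nn1)C(F)(F)F` is not yet measured. It differs from compound 1 in one place: ((2-fluorophenyl)carbamoyl)methyl in place of 4-fluorophenyl on an aromatic nitrogen. The step from compound 1 to compound 3 introduces the same kind of group at the same place and is the one that bears directly on this change; it was large. For compound 4 a step of like direction and size is therefore expected, a 13-fold higher number from compound 1 to compound 4 (1.12 log units; beyond the scatter) in this assay. Compound 4 is expected to give about 120000 nM in this assay, within 35000 nM to 400000 nM, and quite possibly only the limit of > 150000 nM in this assay, at which 1 of the 3 values shown sits, will be reported.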

Compound 4, half-maximal inhibitory concentration: 42100 nM
Beside the measured number, compound 4's estimate is 2.9-fold (0.45 log units) above it; the measured number falls inside the stated range.
By their numbers in this assay, from the lowest: compound 1; then compounds 2 and 4 (each within the scatter of the next). At a limit, above all of these: compound 3.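

The ((2-fluorophenyl)carbamoyl)methyl group on the aromatic nitrogen is not tied to the limit seen with its bromo relative, although it still gives up ground to 4-fluorophenyl: a 4.6-fold higher number from compound 1 to compound 4 (0.67 log units; beyond the scatter). The halogen on that group's aromatic carbon matters, and this reading rests on a limit, not a number: an at least 3.5-fold lower number from compound 3 to compound 4 (0.55 log units; beyond the scatter). Against 4-methylphenyl, the entering group is not separated: a 1.6-fold higher number from compound 2 to compound 4 (0.20 log units; within the scatter).

The compounds shown do not tell the contribution of the amide hydrogen, the carbonyl and the added length of the entering group apart, nor do they show how far the halogen effect extends beyond fluoro and bromo. A plain benzyl group on the same nitrogen, or a chloro in place of the fluoro, would address these points.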